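Swapping the benzyl for a plain phenyl on the piperazine nitrogen

A few compounds are considered here, and "the series" means these few. Any claim that something is new, unique, unknown or untested is made for them only; others in the source may bear on it.

Of the compounds shown here, three sharing one core have been measured in an assay on CHO cells for displacement of a labelled ligand from adenosine receptor A3 (Homo sapiens), read by scintillation counting, with a stated time of 45 min, tested at 1 uM, in the presence of a further agent that is not named here; on this read-out lower numbers stand for less inhibition and higher numbers for more inhibition at the one concentration tested (going by the name of the read-out). Compound 1 `CCCn1c(=O)[nH]c2nc(-c3ccc(S(=O)(=O)N4CCN(c5ccc(F)cc5)CC4)cc3)[nH]c2c1=O` gives 38%. Compound 2 `CCCn1c(=O)[nH]c2nc(-c3ccc(S(=O)(=O)N4CCN(Cc5cccc(C)c5)CC4)cc3)[nH]c2c1=O` gives 17%, the lowest of the three numbers. Compound 3 `CCCn1c(=O)[nH]c2nc(-c3ccc(S(=O)(=O)N4CCN(c5ccc(C)cc5)CC4)cc3)[nH]c2c1=O` gives 25%. Compound 2 lies nearest to compound 3, within the scatter, and furthest from compound 1, a gap that is beyond the scatter.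

Compound 4 `CCCn1c(=O)[nH]c2nc(-c3ccc(S(=O)(=O)N4CCN(c5ccccc5)CC4)cc3)[nH]c2c1=O` has not yet been measured. It differs from compound 2 in one place: phenyl in place of 3-methylbenzyl on an amine nitrogen in a ring.

Two measured steps speak to this change. The closest is a number 8 percentage points higher from compound 2 to compound 3 (within the scatter), where a different aryl group replaced the same 3-methylbenzyl group and the number barely moved. The other is a number 13 percentage points lower from compound 1 to compound 3 (beyond the scatter), which shows how much a single substituent on that aryl ring can shift the number. Compound 4 carries the bare phenyl, with neither the methyl of compound 3 nor the fluoro of compound 1, so its value is expected to fall near those two aryl compounds rather than near compound 2.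

For compound 4 the expected step is therefore a number 11 percentage points higher from compound 2 to compound 4 (beyond the scatter), a small rise that may or may not exceed the scatter. The estimate for compound 4 is 28%, with a range from 12% to 45%.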

Compound 4, a percentage reported as inhibition, at one concentration (the size of the read-out at that concentration, not a potency): 27%
For compound 4 the middle estimate is 1 percentage points above the measured one; low and high end bracket the measured number.
By their numbers in this assay, from the lowest: compounds 2, 3 and 4 (each within the scatter of the next); then compound 1.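

In this assay, the bare phenyl on the amine nitrogen sits level with the 3-methylbenzyl group, a number 10 percentage points higher from compound 2 to compound 4 (within the scatter), so at this position the exchange produces no difference that can be told from the scatter. The new compound also serves as an unsubstituted reference for the aryl ring: taking away the methyl gives a number 2 percentage points higher from compound 3 to compound 4 (within the scatter), which is within the scatter, while taking away the fluoro gives a number 11 percentage points lower from compound 1 to compound 4 (beyond the scatter), a modest step beyond it, so among these compounds only the fluoro sets its compound apart from the bare ring. Nothing available here explains why the fluoro and the methyl differ in this way.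

From the compounds shown here alone, it remains open whether a chloro or a methoxy on the phenyl ring would behave like the fluoro or like the methyl, and whether a plain benzyl group would stay level with the 3-methylbenzyl group and the phenyl. All four numbers also come from a single concentration, so they show the size of the inhibition at that concentration and give no potency for any of the compounds.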